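Estimating a 4-chlorophenyl analogue from three close values

The source may hold more compounds than are shown below. What is called first, only, known or untested is meant among the compounds shown, and "the series" means these compounds.

Compound 1 `COc1cc(/C=C2\CN(C)C/C(=C\c3ccccc3F)C2=O)cc(OC)c1OC` gives 4340 nM in a functional assay on K562 cells (Homo sapiens) for cytotoxicity, read by MTT assay, with a stated time of 24 h; on this read-out higher numbers stand for weaker inhibition and lower numbers for stronger inhibition
Compound 2 `COc1cc(/C=C2\CN(C)C/C(=C\c3cccc([N+](=O)[O-])c3)C2=O)cc(OC)c1` gives 4420 nM in this assay
Compound 3 `COc1cc(/C=C2\CN(C)C/C(=C\c3cc(OC)c(OC)c(OC)c3)C2=O)cc(OC)c1` gives 3470 nM in this assay

In this assay compound 3 stands at 3470 nM and the values of compound 1 and compound 2 lie within the scatter of it. Compound 4 `COc1cc(/C=C2\CN(C)C/C(=C\c3ccc(Cl)cc3)C2=O)cc(OC)c1OC` has not yet been measured. It carries 4-chlorophenyl in place of 3,5-dimethoxyphenyl on a double-bonded chain carbon bound to a double-bonded ring carbon, a change counted as 4-chlorophenyl in place of 3,5-dimethoxyphenyl on a double-bonded chain carbon bound to a double-bonded ring carbon in the structures. Within the data shown here, no measured compound carries 4-chlorophenyl, so the data offer no direct evidence for it.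

Among the measured compounds shown here, one measured step bears on this place. Replacing 2-fluorophenyl with 3,5-dimethoxyphenyl gave a 1.3-fold lower number from compound 1 to compound 3 (0.10 log units; within the scatter) and did not move the value beyond the scatter. On that basis, no shift beyond the scatter is expected in this assay and the expected step is a 1.1-fold higher number from compound 3 to compound 4 (0.04 log units; within the scatter) on this estimate. For compound 4 the estimated value is 3800 nM and the expected range runs from 2000 nM to 7000 nM in this reading.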

Compound 4, half-maximal inhibitory concentration: > 20000 nM
Compound 4: no number, only a limit; the forecaster's own chance of this, stated with the estimate: 3%; at least 5.2-fold (0.72 log units) between middle value and limit.
By their numbers in this assay, from the lowest: compounds 3, 1 and 2 (each within the scatter of the next). At a limit, above all of these: compound 4.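

In this assay compound 4 gives no number, only a limit: the limit of > 20000 nM in this assay, at which 1 of the 4 values shown sits.

This position, the double-bonded chain carbon bound to a double-bonded ring carbon, had shown no change beyond the scatter when 3,5-dimethoxyphenyl replaced 2-fluorophenyl, but it does respond to 4-chlorophenyl. That group gives an at least 5.7-fold higher number from compound 3 to compound 4 (0.76 log units; beyond the scatter) and an at least 4.6-fold higher number from compound 1 to compound 4 (0.66 log units; beyond the scatter), so both steps lie beyond the scatter and the position is not indifferent to the aryl group it carries.

The compounds shown leave open whether 4-fluorophenyl or 4-methoxyphenyl at this place would stay close to compound 1 and compound 3 or follow compound 4. They also leave open how an aryl ring bearing an amine or a carboxylic acid would read here, and how large the step to compound 4 really is.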